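Swapping 3-chlorophenyl for 2,6-dimethylphenyl on compound 3

The source may hold more compounds than are shown below. What is called first, only, known or untested is meant among the compounds shown, and "the series" means these compounds.

compound 1 `CCNc1cc(-c2ccc(NC(=O)Nc3cccc(Cl)c3)cc2C)ccn1`: 16600 nM
compound 2 `CCNc1cc(-c2ccc(NC(=O)Nc3cccc4ccccc34)cc2C)ccn1`: > 30000 nM (a limit of the assay)
compound 3 `CCNc1cc(-c2ccc(NC(=O)Nc3cccc(Cl)c3)cc2C(F)(F)F)ccn1`: 13300 nM

In a functional assay on BT-483 cells (Homo sapiens) for cytotoxicity, read by MTT assay, with a stated time of 24 h (a lower number here means a stronger inhibitor, a higher number a weaker inhibitor), compound 3 gives 13300 nM and stands level with compound 1 within the scatter. Trifluoromethyl in place of methyl amounts to a 1.2-fold lower number from compound 1 to compound 3 (0.10 log units; within the scatter) and shows no measurable change. The value for compound 2 is only a limit.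

Compound 4 `CCNc1cc(-c2ccc(NC(=O)Nc3c(C)cccc3C)cc2C(F)(F)F)ccn1` keeps the rest of compound 3 and carries 2,6-dimethylphenyl in place of 3-chlorophenyl on an amide-type nitrogen. Within the data shown here, one measured step touches this place: naphthalen-1-yl in place of 3-chlorophenyl gave an at least 1.8-fold higher number from compound 1 to compound 2 (0.25 log units; that floor lies within the scatter) on that nitrogen. Its floor lies within the scatter, which makes it a weak guide, but it points towards a higher number. A small rise is therefore expected, possibly no larger than the scatter. For compound 4 the expected change is a 1.5-fold higher number from compound 3 to compound 4 (0.18 log units; within the scatter) by this estimate. The estimate for compound 4 is 20000 nM with an expected range from 8000 nM to 30000 nM in this assay overall.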

Compound 4, half-maximal inhibitory concentration: 22000 nM
Compound 4: the middle estimate sits 1.1-fold (0.04 log units) below what was measured; the measured number falls inside the stated range.
By their numbers in this assay, from the lowest: compounds 3, 1 and 4 (each within the scatter of the next). At a limit, above all of these: compound 2.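

In this assay, 2,6-dimethylphenyl in place of 3-chlorophenyl on the amide-type nitrogen gives a 1.7-fold higher number from compound 3 to compound 4 (0.22 log units; within the scatter). Unlike the step to compound 2, which ends at a limit, this step has a real number at both ends, so it gives a firmer reading of this position. It shows that on the trifluoromethyl compounds, a ring with two methyl groups and no chlorine stands level with the chlorinated ring within the scatter.

All the groups shown on this nitrogen are aromatic rings of carbon only, so it remains open whether a group carrying an amine or a carboxylic acid would shift the number beyond the scatter. Any rise in the number can also be followed only so far: the limit of > 30000 nM in this assay, at which 1 of the 4 values shown sits.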